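The source may hold more compounds than are shown below. What is called first, only, known or untested is meant among the compounds shown, and "the series" means these compounds.

Among the measured compounds shown here, in a functional assay on A549 cells (Homo sapiens) for cytotoxicity, read by MTT assay, with a stated time of 48 h (a lower number here means a stronger inhibitor, a higher number a weaker inhibitor), compound 2 (`COc1ccc(/C=C/c2cc(OC)c(OC)c(OC)c2-c2ccc(Cl)cc2)cc1`) gives 30000 nM as the higher of the two numbers so far, which makes it the weaker inhibitor of the pair. Compound 1 (`COc1ccc(/C=C/c2cc(OC)c(OC)c(OC)c2-c2ccc(F)c(F)c2)cc1`) gives 7500 nM on the same core. Compound 3 (`COc1ccc(/C=C/c2cc(OC)c(OC)c(OC)c2-c2ccc(OC)c(OC)c2)cc1`) keeps that core and differs from compound 2 in one group (3,4-dimethoxyphenyl in place of 4-chlorophenyl on an aromatic carbon): 3,4-dimethoxyphenyl in place of 4-chlorophenyl on an aromatic carbon, ortho to a large group. For the measured compounds named here, only one measured step involves this same place: a 4.0-fold higher number from compound 1 to compound 2 (0.60 log units; beyond the scatter) when 4-chlorophenyl replaces 3,4-difluorophenyl. The new group, like the 3,4-difluorophenyl of compound 1, carries two substituents with the same numbering, but they are different substituents, and a single step is thin evidence. A modest move toward a lower number is therefore expected, and the estimated step is a 2.1-fold lower number from compound 2 to compound 3 (0.33 log units; beyond the scatter) in this assay with wide uncertainty. The value expected for compound 3 is 14000 nM (range 4000 nM to 50000 nM).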

Compound 3, half-maximal inhibitory concentration: 28000 nM
For compound 3 the middle estimate is 2.0-fold (0.30 log units) below the measured one, within the range that was stated.
By their numbers in this assay, from the lowest: compound 1; then compounds 3 and 2 (each within the scatter of the next).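

Swapping 4-chlorophenyl for 3,4-dimethoxyphenyl at this place on the shared core makes no real difference in this assay: the change gives a 1.1-fold lower number from compound 2 to compound 3 (0.03 log units; within the scatter) and so stays inside the normal variation between repeat measurements. Carrying two substituents with the same numbering is therefore not enough on its own to give a lower number, as the change to dimethoxy gives a 3.7-fold higher number from compound 1 to compound 3 (0.57 log units; beyond the scatter) and that gap is a real one. Compound 1 now has the lowest number of the three, with steps beyond the scatter to both compound 2 and compound 3, so what sets it apart lies in its 3,4-difluorophenyl group as a whole.

Still open, from the compounds shown here alone, is whether fluorine itself matters, which a 4-fluorophenyl or a 3,4-dichlorophenyl at the same place could help to test. Nothing available here explains why these groups give the numbers they do.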